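The source may hold more compounds than are shown below. What is called first, only, known or untested is meant among the compounds shown, and "the series" means these compounds.

Measured so far:
- compound 1, `O=C(/C=C/c1ccc(OCc2ccccc2)cc1)c1ccccc1`: 24700 nM
- compound 2, `COc1cccc(/C=C/C(=O)c2ccc(OCc3ccccc3)cc2)c1`: 13700 nM

In a functional assay on CAL-51 cells (Homo sapiens) for inhibition, read by sulforhodamine B assay, with a stated time of 3 days (on this read-out lower numbers stand for stronger inhibition of growth and higher numbers for weaker inhibition of growth), compound 1 gives 24700 nM. Compound 1 stands at one end of the two numbers shown, yet its gap to compound 2 lies within the usual scatter of this assay, so the two compounds cannot be told apart on these data. Compound 3, `O=C(/C=C/c1ccc(F)cc1)c1ccccc1`, has not yet been measured. It differs from compound 1 in one place: fluoro in place of benzyloxy on an aromatic carbon. For the measured compounds named here, no measured pair shows this change, so its effect can only be guessed. A large group that reaches out from the core of compound 1 is replaced by a single small atom; such a loss is expected to weaken growth inhibition somewhat, moving the number of this assay upward by a step that may reach beyond the scatter but need not. Compound 3 is therefore estimated at 40000 nM, with a range from 12000 nM to 120000 nM, the expected step being a 1.6-fold higher number from compound 1 to compound 3 (0.21 log units; within the scatter).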

Compound 3, concentration for 50% growth inhibition: 2780 nM
For compound 3 the middle estimate is 14-fold (1.16 log units) above the measured one; measured number outside the range, below it.
By their numbers in this assay, from the lowest: compound 3; then compounds 2 and 1 (each within the scatter of the next).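

In this assay, for the compounds shown here, fluoro in place of benzyloxy gives an 8.9-fold lower number from compound 1 to compound 3 (0.95 log units; beyond the scatter) and this is the first step that lies beyond the scatter. This aromatic carbon therefore does not need the large benzyloxy group, with its extra ring, for growth inhibition in these cells: of this pair, the compound carrying a single fluorine atom inhibits growth more strongly. No measurement available here explains why the much smaller group does better.

Going by these compounds alone, with only two groups compared at this position, it remains open whether the gain comes from losing the benzyloxy group or from having fluoro in particular. A plain hydrogen, a chloro group or an amine on the same carbon would help to separate these two readings.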